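Methyl for Phenoxy on a Seven-Membered Ring and Paw Edema

The compounds below may be only part of what the source reports. "The series", "measured", "known", "first", "only" and "open" are said of these compounds alone.

Measured compounds:
compound 1, `CCOC(=O)C(=O)Nc1c(Oc2ccccc2)ccccc1=O`, 0%
compound 2, `CCOC(=O)C(=O)Nc1ccccc(Oc2ccccc2)c1=O`, 16%
compound 3, `CCOC(=O)C(=O)Nc1c(C)ccccc1=O`, 47%

All three were tested in a functional assay on the whole organism (strain Sprague-Dawley CD) for inhibition, with Rattus norvegicus as the target, read by paw edema, at a dose of 30 mg/kg by the intraperitoneal route; a higher number here means a stronger effect of the compound at the dose given, a lower number a weaker effect. Compound 1 gives 0%, while compound 3 gives 47%. These two differ in one place, (methyl in place of phenoxy on an aromatic carbon), and that single change made a step of a number 47 percentage points higher from compound 1 to compound 3 (beyond the scatter).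

Compound 2 has the same atoms as compound 1 joined in a different way; the difference between the two cores is not broken down here. Compound 2 gives 16%, which lies between the other two measured numbers and beyond the usual scatter from each of them.

Compound 4, `CCOC(=O)C(=O)Nc1ccccc(C)c1=O`, has not yet been measured. It is made from compound 2 by methyl in place of phenoxy on an aromatic carbon. Within the data shown here, this is the same kind of change as the one from compound 1 to compound 3, but not the same: in compound 3 the methyl sits next to the ring atom that bears a group of 8 heavy atoms, whereas in compound 4 it sits two ring bonds from that ring atom.

Among the measured compounds shown here, the only guide is the single step seen between compound 1 and compound 3, a number 47 percentage points higher from compound 1 to compound 3 (beyond the scatter). Because that step was a number 47 percentage points higher from compound 1 to compound 3 (beyond the scatter), compound 4 is expected to gain over compound 2 by about a number 29 percentage points higher from compound 2 to compound 4 (beyond the scatter). For the measured compounds named here, the different place of the change and the single example behind it leave the expectation wide. In this assay compound 4 is estimated to give 45%, within a range from 15% to 70%.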

Compound 4, a percentage reported as inhibition, in the whole organism at one dose (the size of the read-out at that dose, not a potency): 60%
Estimate against measurement, compound 4: 15 percentage points below, and the stated range covers the measured number.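

In this assay, methyl in place of phenoxy on the core of compound 2 gives a step of a number 44 percentage points higher from compound 2 to compound 4 (beyond the scatter), and set beside the earlier step on the core of compound 1, the two agree in size: the same change on two cores in this assay, a number 47 percentage points higher (beyond the scatter) from compound 1 to compound 3 and a number 44 percentage points higher (beyond the scatter) from compound 2 to compound 4, 3 percentage points apart, within the scatter of two such steps

So, on these two cores, this change carried over with much the same size, even though the changed carbon does not have the same place in the two pairs; in compound 4 it lies two ring bonds from the ring atom that bears a group of 8 heavy atoms. Among these compounds, this does not show that the step would hold on any other core, since it rests on only two pairs at a single dose, and it cannot say whether losing phenoxy or gaining methyl matters more, nor why the numbers rise.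

The compounds shown carry only phenoxy or methyl on this carbon, so what a longer chain such as propyl or an amine would give there stays open. The group of 8 heavy atoms is the same in all four compounds, which also leaves open what a carboxylic acid at the end of that group would do.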